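The source may hold more compounds than are shown below. What is called first, only, known or untested is meant among the compounds shown, and "the series" means these compounds.

Measured so far in an assay on CHO cells for displacement of a labelled ligand from prostaglandin D2 receptor 2 (Homo sapiens), read by scintillation counting; a lower number here means a stronger inhibitor, a higher number a weaker inhibitor:
compound 1 `COCCN(C)S(=O)(=O)c1ccc(C)c(C#Cc2cc(Cl)ccc2OCC(=O)O)c1` gives 4.1 nM
compound 2 `Cc1ccc(S(=O)(=O)CCO)cc1C#Cc1cc(Cl)ccc1OCC(=O)O` gives 19 nM
compound 3 `Cc1ccc(S(=O)(=O)NC(C)C)cc1C#Cc1cc(Cl)ccc1OCC(=O)O` gives 3.4 nM

Compound 3 carries the lowest number of the three, but its gap to compound 1 is within the scatter, as the step of a 1.2-fold lower number from compound 1 to compound 3 (0.08 log units; within the scatter) shows. Only compound 2 stands clearly apart: the step of a 5.6-fold lower number from compound 2 to compound 3 (0.75 log units; beyond the scatter) is beyond the scatter, and the step of a 4.6-fold higher number from compound 1 to compound 2 (0.67 log units; beyond the scatter) points the same way.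

Compound 4 `Cc1ccc(S(=O)(=O)N2CCOCC2)cc1C#Cc1cc(Cl)ccc1OCC(=O)O` is not yet measured. It differs from compound 3 in one place: morpholin-4-yl in place of isopropylamino on a sulfonyl sulfur. Like the (2-methoxyethyl)(methyl)amino group of compound 1, the entering morpholin-4-yl keeps a nitrogen on the sulfonyl sulfur, brings an oxygen and has no hydrogen-bond donor. The step that bears on it most directly is therefore the one between the two nitrogen-bearing groups, a 1.2-fold lower number from compound 1 to compound 3 (0.08 log units; within the scatter), which lay within the scatter. The two steps involving compound 2 concern a group without nitrogen and are less informative here. The step from compound 3 to compound 4 is accordingly expected to be small, a 1.5-fold higher number from compound 3 to compound 4 (0.17 log units; within the scatter), not beyond the scatter. Compound 4 is estimated at 5 nM, with a range from 2 nM to 15 nM.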

Compound 4, inhibition constant: 3.6 nM
The estimate for compound 4 lay 1.4-fold (0.14 log units) above the measured number, within the range that was stated.
By their numbers in this assay, from the lowest: compounds 3, 4 and 1 (each within the scatter of the next); then compound 2.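

In this assay, morpholin-4-yl on the sulfonyl sulfur gives a result within the scatter of isopropylamino (a 1.1-fold higher number from compound 3 to compound 4 (0.02 log units; within the scatter)), so exchanging a group with a hydrogen-bond donor and no ring for one with a six-membered non-aromatic ring and no hydrogen-bond donor leaves no readable difference in this pair. The comparison with the open-chain group is also within the scatter (a 1.1-fold lower number from compound 1 to compound 4 (0.06 log units; within the scatter)), which places a ring and two different open-chain nitrogen-bearing groups together at this position across compounds 1, 3 and 4. The step from the 2-hydroxyethyl group is beyond the scatter (a 5.3-fold lower number from compound 2 to compound 4 (0.72 log units; beyond the scatter)), leaving compound 2, the only one here without a nitrogen on the sulfonyl sulfur, clearly apart, but nothing available explains that separation.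

Piperidin-1-yl would show whether the ring oxygen of morpholin-4-yl matters at all, while a piperazine or an unsubstituted amino group would extend the nitrogen-bearing set in other directions. A 2-methoxyethyl group placed directly on the sulfonyl sulfur would help separate the loss of the nitrogen from the presence of the hydroxyl in compound 2.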